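A few compounds are considered here, and "the series" means these few. Any claim that something is new, unique, unknown or untested is made for them only; others in the source may bear on it.

Working notes on the series. All three measured compounds share one core and differ only in the aryl group carried on it. Compound 1 `COc1ccccc1N1CCN(CCCCC(=O)NCc2ccccc2-c2c(OC)cccc2OC)CC1` gives 32.4 nM in an assay on CHO-K1 cells for displacement of a labelled ligand from 5-hydroxytryptamine receptor 7 (Homo sapiens), read by scintillation counting; on this read-out higher numbers stand for weaker inhibition and lower numbers for stronger inhibition. Compound 2 `COc1ccccc1N1CCN(CCCCC(=O)NCc2ccccc2-c2ccccc2F)CC1` gives 36.5 nM in this assay. Compound 3 `COc1ccccc1N1CCN(CCCCC(=O)NCc2ccccc2-c2ccccc2C)CC1` gives 26.1 nM in this assay. The numbers sit close together: a 1.1-fold higher number from compound 1 to compound 2 (0.05 log units; within the scatter), a 1.2-fold lower number from compound 1 to compound 3 (0.09 log units; within the scatter) and a 1.4-fold lower number from compound 2 to compound 3 (0.15 log units; within the scatter). Compound 3 carries the lowest of the three numbers, but its distance to compound 1 and to compound 2 lies within the scatter, so no order among the three follows from these values.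

Compound 4 `COc1ccccc1N1CCN(CCCCC(=O)NCc2ccccc2-c2cccc(C)c2)CC1` has not been measured. Its difference from compound 3 is 3-methylphenyl in place of 2-methylphenyl on an aromatic carbon. For the measured compounds named here, no measured step moves a substituent to another position on this ring; the three steps above each swap one group for another at a single place, and all of them stay within the scatter. The record thus speaks only for tolerance of varied groups at that place, and gives no direct guide for the present change. The step from compound 3 to compound 4 is expected to be about a 1.5-fold higher number from compound 3 to compound 4 (0.16 log units; within the scatter), not clearly beyond the scatter. Compound 4 is estimated at 38 nM in this assay, with a range of 15 nM to 95 nM.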

Compound 4, inhibition constant: 47.6 nM
Compound 4: middle estimate off by 1.3-fold (0.10 log units), on the low side; low and high end bracket the measured number.
By their numbers in this assay, from the lowest: compounds 3, 1, 2 and 4 (each within the scatter of the next).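

Placing the methyl group as in 3-methylphenyl rather than 2-methylphenyl is the first change of position on this ring in the series, and in this assay it stays within the scatter (a 1.8-fold higher number from compound 3 to compound 4 (0.26 log units; within the scatter)). Compound 4 also stays within the scatter of the two other aryl groups (a 1.3-fold higher number from compound 2 to compound 4 (0.12 log units; within the scatter); a 1.5-fold higher number from compound 1 to compound 4 (0.17 log units; within the scatter)), so 3-methylphenyl joins the groups tolerated at this place and no order among the four compounds follows from these values. Nothing at hand offers an explanation for the size of the step from 2-methylphenyl to 3-methylphenyl.

The compounds shown leave open whether any group at this place gives a step beyond the scatter, since all of them so far are aryl rings of carbon only, carrying methyl, fluoro or methoxy groups. An amine, a carboxylic acid or a nitrile on this aryl ring would test that limit, and a longer chain in the shared core would show whether the tolerance seen here holds when the aryl group is carried further out.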